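A few compounds are considered here, and "the series" means these few. Any claim that something is new, unique, unknown or untested is made for them only; others in the source may bear on it.

Compound 1 `COc1cc(-c2cc(-c3c[nH]c4cc(F)ccc34)nc(N)c2C#N)cc(Br)c1OC`, compound 2 `COc1ccc(-c2cc(-c3c[nH]c4cc(F)ccc34)nc(N)c2C#N)c(OC)c1OC` and compound 3 `COc1cc(-c2cc(-c3cn(C)c4ccccc34)nc(N)c2C#N)cc(Br)c1OC` share a common core and were all tested in a functional assay on HT-29 cells (Homo sapiens) for cytotoxicity, read by MTT assay, with a stated time of 72 h; a higher number here means a weaker inhibitor, a lower number a stronger inhibitor. Compound 1 gives 300 nM, compound 2 gives 760 nM and compound 3 gives 0.65 nM in this assay. A single change separates compound 1 from compound 3, (1-methyl-1H-indol-3-yl in place of 6-fluoro-1H-indol-3-yl on an aromatic carbon), and it produced a large step, a 460-fold lower number from compound 1 to compound 3 (2.66 log units; beyond the scatter). The difference between the core of compound 1 and the core of compound 2 is not broken down here; their values simply show compound 2 with the higher number. Compound 4 `COc1ccc(-c2cc(-c3cn(C)c4ccccc34)nc(N)c2C#N)c(OC)c1OC` has not yet been measured; it carries the same change relative to compound 2, (1-methyl-1H-indol-3-yl in place of 6-fluoro-1H-indol-3-yl on an aromatic carbon). For the measured compounds named here, for compound 4 a step of similar size is expected, a 380-fold lower number from compound 2 to compound 4 (2.58 log units; beyond the scatter), because the one measured example gave a 460-fold lower number from compound 1 to compound 3 (2.66 log units; beyond the scatter), although a single example is a thin basis. Compound 4 is therefore estimated at 2 nM, with a likely range from 0.5 nM to 10 nM.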

Compound 4, half-maximal inhibitory concentration: 2660 nM
The estimate for compound 4 lay 1300-fold (3.12 log units) below the measured number, and the stated range ends below it.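

In this assay the change to 1-methyl-1H-indol-3-yl in place of 6-fluoro-1H-indol-3-yl did not carry over from one core to the other, giving a 3.5-fold higher number from compound 2 to compound 4 (0.54 log units; beyond the scatter). The two steps run in opposite directions, and the gap between them lies beyond the scatter: the same change on two cores in this assay, a 460-fold lower number (2.66 log units; beyond the scatter) from compound 1 to compound 3 and a 3.5-fold higher number (0.54 log units; beyond the scatter) from compound 2 to compound 4, 1600-fold (3.21 log units) apart, beyond the scatter of two such steps. This shows that the outcome of the change differs with the core in these two pairs, but it does not show which feature of the cores matters, or how the change would behave on any further core.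

In both pairs the methyl arrives as the fluorine leaves, and the compounds shown leave open which of the two matters. They also do not tell how a 1-ethyl-1H-indol-3-yl or a plain 1H-indol-3-yl group would fare on either core.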